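Chain ether for hydroxyl: cytotoxicity expectation in the series

The source may hold more compounds than are shown below. What is called first, only, known or untested is meant among the compounds shown, and "the series" means these compounds.

In an ADME assay on HEp-2 cells (Homo sapiens) for cytotoxicity, with a stated time of 4 days (on this read-out higher numbers stand for lower toxicity in this test and lower numbers for higher toxicity in this test), compound 1 `CNS(=O)(=O)c1cn(Cc2nc3cc(Cl)ccc3n2CCCS(C)(=O)=O)c2ccccc12` gives only a limit, > 100000 nM. Compound 2 `CS(=O)(=O)c1nn(Cc2nc3cc(Cl)ccc3n2CCCO)c2cnccc12` likewise gives only a limit in this assay, > 100000 nM. Compound 2 therefore stands with compound 1 at the limit of > 100000 nM in this assay, at which 2 of the 2 values shown sit, with no numbered value anywhere in the pair. Compound 3 `COCCOCCn1c(Cn2nc(S(C)(=O)=O)c3ccncc32)nc2cc(Cl)ccc21` carries 2-methoxyethoxy in place of hydroxymethyl on a saturated chain carbon, two bonds along the chain from an aromatic nitrogen, 2-methoxyethoxy in place of hydroxymethyl on a saturated chain carbon, two bonds along the chain from an aromatic nitrogen. With both measured values sitting at the limit of > 100000 nM in this assay, at which 2 of the 2 values shown sit, the step from compound 2 to compound 3 is expected to be a number no higher from compound 2 to compound 3 (the limit leaves the size open), none beyond the scatter. Compound 3 is estimated at 100000 nM, within 40000 nM to 300000 nM, most probably again reported only as a limit.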

Compound 3, half-maximal cytotoxic concentration: > 100000 nM
Compound 3 gave a limit, no number; the forecaster's own chance of this, stated with the estimate: 85%; the middle value lies on the limit itself.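

No step can be read from compound 2 to compound 3 in this assay, both values being limits: the limit of > 100000 nM in this assay, at which 3 of the 3 values shown sit.

Whether 2-methoxyethoxy in place of hydroxymethyl shifts the read-out at all stays open; none of the compounds shown carries a numbered value.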